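Dropping a Bromine From the Anilino Ring

A few compounds are considered here, and "the series" means these few. Any claim that something is new, unique, unknown or untested is made for them only; others in the source may bear on it.

Compound 1 `Clc1ccc(NCc2cn(-c3ccccc3)nc2-c2ccc(Br)cc2)cc1`: > 100000 nM; > 100000 nM (2 entries)
Compound 2 `Brc1ccc(NCc2cn(-c3ccccc3)nc2-c2ccc(Br)cc2)cc1`: > 100000 nM

Both compounds were tested in an ADME assay on BHK-21 cells (Mesocricetus auratus) for cytotoxicity, read by MTT assay, with a stated time of 72 h; a lower number here means that less compound is tolerated, a higher number that more compound is tolerated. Compound 1 is reported only as a limit, > 100000 nM; > 100000 nM (2 entries), in each of its two entries. Compound 2 also gives only a limit, > 100000 nM, and its further entry carries no single number either. Compound 2 therefore stands at the ceiling of this assay rather than at a measured number, the same reading as the limit of > 100000 nM in this assay, at which 1 of the 2 values shown sits. Compound 3 `Brc1ccc(-c2nn(-c3ccccc3)cc2CNc2ccccc2)cc1` has not yet been tested. It differs from compound 2 by hydrogen in place of bromo on an aromatic carbon: bromo leaves and hydrogen enters on an aromatic carbon of a six-membered aromatic ring of carbon only, so the (4-bromophenyl)amino becomes an anilino. Among the compounds with values here, no step between two measured compounds is available, and the two limits give no trend to build on. The expected step is a number no higher from compound 2 to compound 3 (the limit leaves the size open), none beyond the scatter in either direction. Compound 3 is thus estimated at about 100000 nM, within 50000 nM to 300000 nM, and will most likely again be reported only as a limit.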

Compound 3, half-maximal cytotoxic concentration: > 100000 nM
Compound 3: no number, only a limit; the forecaster's own chance of this, stated with the estimate: 80%; the middle value lies on the limit itself.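

Compound 3 also gives only a limit, > 100000 nM, in this assay, so no step from compound 2 to compound 3 can be read: the limit of > 100000 nM in this assay, at which 2 of the 3 values shown sit.

The compounds shown leave open at what concentration any of them harms these cells, and whether hydrogen in place of bromo changes that concentration at all.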